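Cytotoxicity notes on a benzylimidazole aniline series

A few compounds are considered here, and "the series" means these few. Any claim that something is new, unique, unknown or untested is made for them only; others in the source may bear on it.

Measured compounds:
- Compound 1, `COC(=O)c1ccc(NCc2cncn2Cc2cccc(C#N)c2)cc1-c1ccccc1`: in a toxicity assay on NIH3T3 cells (Mus musculus) for cytotoxicity, read by resazurin assay (on this read-out higher numbers stand for an effect only at larger amounts of compound and lower numbers for an effect already at smaller amounts), compound 1 gives > 10000 nM, a limit of the assay.
- Compound 2, `COC(=O)c1ccc(NCc2cncn2Cc2ccccc2-c2ccccc2)cc1-c1ccccc1`: in this assay compound 2 gives "not determined" (no result reported).
- Compound 3, `COC(=O)c1ccc(NCc2cncn2Cc2cccc(N)c2)cc1-c1ccccc1`: in this assay compound 3 gives > 10000 nM, again a limit of the assay.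

Compound 3 stands where compound 1 stands: at the limit of this assay, with no number behind it. For the measured compounds named here, the only single-point step among the measured compounds, a step that the two limits leave unreadable from compound 1 to compound 3, cannot be read because of the limit of > 10000 nM in this assay, at which 2 of the 3 values shown sit.

The next compound is compound 4, `COC(=O)c1ccc(NCc2cncn2Cc2ccccc2)cc1-c1ccccc1`. It differs from compound 3 by hydrogen in place of amino on an aromatic carbon. Going by the values given here, no measured step bears directly on this change; the one step that exists, a step that the two limits leave unreadable from compound 1 to compound 3, is itself unreadable, and compound 2 carries no value at all.

With both measured neighbours sitting at the limit, compound 4 is expected to stay at or beyond that limit in this assay, so the step that the limit leaves unreadable from compound 3 to compound 4 is estimated as none beyond the scatter. Compound 4 is therefore expected to give about 20000 nM in this assay, within 8000 nM to 60000 nM, most likely reported again only as a limit.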

Compound 4, half-maximal effective concentration: > 1000 nM
Compound 4 gave a limit, no number; the forecaster's own chance of this, stated with the estimate: 85%; the middle value does not contradict the limit.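

Neither step to compound 4, from compound 1 or from compound 3, can be read in this assay: all three results are limits, not numbers. Left open is the concentration at which compound 1, compound 3 or compound 4 would show an effect in this assay, and so whether cyano, amino or hydrogen on that aromatic carbon makes any difference.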